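The compounds below may be only part of what the source reports. "The series", "measured", "known", "first", "only" and "open" are said of these compounds alone.

Compound 1 `Cc1cc(-c2sc(Cc3cccc(C(F)(F)F)c3)nc2C)ccc1C(N)=O` gives 73 nM in a functional assay on cells for agonist activity at G-protein coupled receptor 52 (Homo sapiens), read by AlphaScreen and cAMP accumulation, with a stated time of 30 min; on this read-out lower numbers stand for an effect already at smaller amounts and higher numbers for an effect only at larger amounts of compound; compound 2 `Cc1cc(-c2sc(Cc3cccc(F)c3)nc2C)ccc1C(N)=O` gives 260 nM; compound 3 `Cc1cc(-c2sc(Cc3cc(F)cc(Cl)c3)nc2C)ccc1C(N)=O` gives 25 nM.

Compound 3 thus shows the lowest number of the three, with compound 1 nearest and compound 2 furthest, both gaps beyond the scatter. Compound 4 `Cc1cc(-c2sc(Cc3cc(F)cc(C(F)(F)F)c3)nc2C)ccc1C(N)=O` differs from compound 3 by trifluoromethyl in place of chloro on an aromatic carbon. Among the compounds with values here, two measured steps bear on this: a 3.6-fold higher number from compound 1 to compound 2 (0.55 log units; beyond the scatter) and a 10-fold lower number from compound 2 to compound 3 (1.02 log units; beyond the scatter). Neither compares trifluoromethyl with chloro directly, yet both show that a group at this position other than hydrogen or fluoro gives the lower numbers. Compound 4 is therefore estimated at 25 nM, within 8 nM to 75 nM. The expected step of no change at the digits printed from compound 3 to compound 4 (within the scatter) lies within the scatter.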

Compound 4, half-maximal effective concentration: 11 nM
Beside the measured number, compound 4's estimate is 2.3-fold (0.36 log units) above it, and the stated range covers the measured number.
By their numbers in this assay, from the lowest: compound 4; then compound 3; then compound 1; then compound 2.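

In this assay, within the data shown here, trifluoromethyl on this aromatic carbon gives a lower number than chloro, with a 2.3-fold lower number from compound 3 to compound 4 (0.36 log units; beyond the scatter) as the first direct comparison of the two groups. The step is larger with trifluoromethyl in place of hydrogen, at a 24-fold lower number from compound 2 to compound 4 (1.37 log units; beyond the scatter), and fluoro in place of hydrogen still counts with trifluoromethyl kept, at a 6.6-fold lower number from compound 1 to compound 4 (0.82 log units; beyond the scatter) and with compound 4 lowest of the four. Nothing measured here accounts for these steps. Still open, as far as these compounds go, is how a nitrile, a methoxy group or an amine would read at this carbon. Also open, from the compounds shown here alone, is whether another group could replace the fluoro group with trifluoromethyl kept.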